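Series notes: halogen swap on the aryl ring, compound 4

A few compounds are considered here, and "the series" means these few. Any claim that something is new, unique, unknown or untested is made for them only; others in the source may bear on it.

Measured so far in a functional assay for inhibition, using microsomes, tested at 100 ug/mL; on this read-out higher numbers stand for a weaker effect at the one concentration tested and lower numbers for a stronger effect:
compound 1 `CCOC(=O)C1=C(C)N(c2ccccc2)C=CC1c1ccccc1`, -19.9%
compound 2 `CCOC(=O)C1=C(C)N(c2ccc(C)cc2)C=CC1c1ccccc1`, -23.5%
compound 3 `CCOC(=O)C1=C(C)N(c2ccc(Cl)cc2)C=CC1c1ccccc1`, -25.5%

Compound 3 gives the lowest of the three numbers, but its steps to the others, a number 5.6 percentage points lower from compound 1 to compound 3 (within the scatter) and a number 2 percentage points lower from compound 2 to compound 3 (within the scatter), lie within the scatter, as does a number 3.6 percentage points lower from compound 1 to compound 2 (within the scatter). The three measured compounds are therefore not separable in this assay.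

Compound 4 `CCOC(=O)C1=C(C)N(c2ccc(Br)cc2)C=CC1c1ccccc1` differs from compound 3 in one place: bromo in place of chloro on an aromatic carbon. Going by the values given here, no measured step exchanges one halogen for another. The nearest bearings are the chloro-for-hydrogen step a number 5.6 percentage points lower from compound 1 to compound 3 (within the scatter) and the chloro-for-methyl step a number 2 percentage points lower from compound 2 to compound 3 (within the scatter), both within the scatter. Changes at this place have moved the read-out little so far, so no step beyond the scatter is expected. The estimated step is a number 0.5 percentage points lower from compound 3 to compound 4 (within the scatter). For compound 4 in this assay the expected value is -26%, with a range from -38% to -14%.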

Compound 4, a percentage reported as activity, at one concentration (the size of the read-out at that concentration, not a potency): -20.7%
Estimate against measurement, compound 4: 5.3 percentage points below, and the stated range covers the measured number.
By their numbers in this assay, from the lowest: compounds 3, 2, 4 and 1 (each within the scatter of the next).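

Going by these compounds alone, the first exchange of one halogen for another at this place, 4-chlorophenyl to 4-bromophenyl, gives a number 4.8 percentage points higher from compound 3 to compound 4 (within the scatter) in this assay and so stays within the scatter. Bromo is also not separable from methyl, with a number 2.8 percentage points higher from compound 2 to compound 4 (within the scatter), or from hydrogen, with a number 0.8 percentage points lower from compound 1 to compound 4 (within the scatter), so the read-out still resolves none of the four groups tried here. Nothing available explains these small steps.

Going by these compounds, whether an amine, a carboxylic acid or a longer chain at this place would give a step beyond the scatter remains open. So does the effect of changes elsewhere on the shared core.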